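The compounds below may be only part of what the source reports. "The series", "measured", "known", "first", "only" and "open" are said of these compounds alone.

Measured compounds:
compound 1, `COc1cc(-c2cc(/C=C/C(=O)c3ccc(Cl)c(Cl)c3)[nH]n2)cc(OC)c1OC`, 87%
compound 2, `COc1ccc(C(=O)/C=C/c2cc(-c3cc(OC)c(OC)c(OC)c3)n[nH]2)cc1OC`, 98%

In a functional assay on T47D cells (Homo sapiens) for cytotoxicity, read by sulforhodamine B assay, with a stated time of 48 h, tested at 0.1 uM (a lower number here means a stronger effect, a higher number a weaker effect of the compound at the concentration tested), compound 2 stands highest of the two numbers, with compound 1 the nearer one, lower than it. Compound 3, `COc1cc(-c2cc(/C=C/C(=O)c3ccc(F)c(F)c3)[nH]n2)cc(OC)c1OC`, differs from compound 2 by 3,4-difluorophenyl in place of 3,4-dimethoxyphenyl on a carbonyl carbon. Among the measured compounds shown here, the only step that bears on this change is a number 11 percentage points higher from compound 1 to compound 2 (beyond the scatter), where a halogen-bearing ring gave way to the dimethoxy ring; here a halogen-bearing ring enters in its place, so the reverse direction is expected. The step from compound 2 to compound 3 in this assay is estimated at a number 10 percentage points lower from compound 2 to compound 3 (within the scatter), and compound 3 is expected to give about 88%, between 75% and 100%.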

Compound 3, a percentage reported as activity, at one concentration (the size of the read-out at that concentration, not a potency): 93%
Estimate against measurement, compound 3: 5 percentage points below; the measured number falls inside the stated range.
By their numbers in this assay, from the lowest: compounds 1, 3 and 2 (each within the scatter of the next, the first and the last beyond it).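

In this assay the 3,4-difluorophenyl ring on the carbonyl carbon stays within the scatter of both other rings, with a number 5 percentage points lower from compound 2 to compound 3 (within the scatter) and a number 6 percentage points higher from compound 1 to compound 3 (within the scatter) as its two steps. Among the compounds shown here, the one step beyond the scatter, between the 3,4-dichlorophenyl and 3,4-dimethoxyphenyl rings, therefore does not extend to a clean split between halogen-bearing and methoxy-bearing rings. No measurement given here explains these numbers.

Open, as far as these compounds go, is how a ring carrying an amine or a carboxylic acid would read at this carbonyl carbon. Also open, from the compounds shown here alone, is whether these rings would separate at other concentrations.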